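Methoxy for amino on the fused core

A few compounds are considered here, and "the series" means these few. Any claim that something is new, unique, unknown or untested is made for them only; others in the source may bear on it.

Among the compounds with values here, compound 1 `Nc1ccn2nc(-c3ccc(F)cc3)c(-c3ccnc(NC4CCCC4)n3)c2c1` is the only member of the series with a number: in an ADME assay on Vero cells (Chlorocebus sabaeus) for cytotoxicity (on this read-out lower numbers stand for higher toxicity in this test and higher numbers for lower toxicity in this test), compound 1 gives 20000 nM. Compound 2 `Fc1ccc(-c2nn3c(Cl)cc(NC4CCCC4)cc3c2-c2ccnc(NC3CCCC3)n2)cc1` reaches only a limit of this assay, > 40000 nM. Compound 3 `CSc1cc(NC2CCCC2)cc2c(-c3ccnc(NC4CCCC4)n3)c(-c3ccc(F)cc3)nn12` likewise stops at a limit of this assay, > 40000 nM. The methylsulfanyl in place of chloro gives a step that the two limits leave unreadable from compound 2 to compound 3, because both values sit at the limit of > 40000 nM in this assay, at which 2 of the 3 values shown sit. Compound 4 `COc1ccn2nc(-c3ccc(F)cc3)c(-c3ccnc(NC4CCCC4)n3)c2c1` differs from compound 1 by methoxy in place of amino on an aromatic carbon. Within the data shown here, no measured step touches this position, so the series offers no guide beyond the scatter. The expected step in this assay is a 1.5-fold higher number from compound 1 to compound 4 (0.18 log units; within the scatter), within the scatter. Compound 4 is estimated at 30000 nM, with a range from 15000 nM to 60000 nM.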

Compound 4, half-maximal cytotoxic concentration: > 36000 nM
Compound 4: a limit, no number; the forecaster's own chance of this, stated with the estimate: 40%; middle value at least 1.2-fold (0.07 log units) from the limit.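

In this assay, methoxy in place of amino on this aromatic carbon gives an at least 1.8-fold higher number from compound 1 to compound 4 (0.25 log units; that floor lies within the scatter). Within the data shown here, exchanging the amino group, with its hydrogen-bond donor, for methoxy therefore brings no drop in the number at this position, which no earlier step could show. Compound 4 gives a limit and no number, so the step has only a floor: the limit of > 36000 nM in this assay, at which 1 of the 4 values shown sits.

On these data alone, the true size of this step remains open. Also open, as far as these compounds go, is whether a carboxylic acid or a dimethylamino group on this aromatic carbon would give a readable number in this assay.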